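The source may hold more compounds than are shown below. What is called first, only, known or untested is meant among the compounds shown, and "the series" means these compounds.

Measured so far:
compound 1 `Cc1ccc(C(=O)Nc2sc3c(c2C(N)=O)CCN(Cc2c(Cl)cccc2Cl)C3)cc1` 12300 nM
compound 2 `NC(=O)c1c(NC(=O)c2cccc([N+](=O)[O-])c2)sc2c1CCN(Cc1c(Cl)cccc1Cl)C2` 13500 nM
compound 3 `Cc1ccc(C(=O)Nc2sc3c(c2C(N)=O)CCN(C(=S)Nc2ccccc2Cl)C3)cc1` 11300 nM

Of the compounds shown here, three have been tested in a functional assay on MKN-74 cells (Homo sapiens) for antiproliferative activity, with a stated time of 24 h; on this read-out lower numbers stand for stronger inhibition and higher numbers for weaker inhibition. Compound 1 `Cc1ccc(C(=O)Nc2sc3c(c2C(N)=O)CCN(Cc2c(Cl)cccc2Cl)C3)cc1` gives 12300 nM. Compound 2 `NC(=O)c1c(NC(=O)c2cccc([N+](=O)[O-])c2)sc2c1CCN(Cc1c(Cl)cccc1Cl)C2` gives 13500 nM; it is made from compound 1 by the change (3-nitrophenyl in place of 4-methylphenyl on a carbonyl carbon), and the step is a 1.1-fold higher number from compound 1 to compound 2 (0.04 log units; within the scatter). Compound 3 `Cc1ccc(C(=O)Nc2sc3c(c2C(N)=O)CCN(C(=S)Nc2ccccc2Cl)C3)cc1` gives 11300 nM; it differs from compound 1 by the change (a group of 10 heavy atoms (7 carbon, 1 nitrogen, 1 sulfur, 1 chlorine; one six-membered aromatic ring of carbon only) in place of a group of 9 heavy atoms (7 carbon, 2 chlorine; one six-membered aromatic ring of carbon only), on an amine nitrogen in a ring), with the step of a 1.1-fold lower number from compound 1 to compound 3 (0.04 log units; within the scatter). All three numbers lie within the scatter of one another, so none can be set apart from the rest.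

Compound 4 `NC(=O)c1c(NC(=O)c2cccc([N+](=O)[O-])c2)sc2c1CCN(C(=S)Nc1ccccc1Cl)C2` has not yet been measured. It stands to compound 3 as compound 2 stands to compound 1: the change is 3-nitrophenyl in place of 4-methylphenyl on a carbonyl carbon, and the surroundings of the place are the same in words as for the change from compound 1 to compound 2, so this is the same change made on a different core, the two cores differing by a group of 10 heavy atoms (7 carbon, 1 nitrogen, 1 sulfur, 1 chlorine; one six-membered aromatic ring of carbon only) in place of a group of 9 heavy atoms (7 carbon, 2 chlorine; one six-membered aromatic ring of carbon only), on an amine nitrogen in a ring.

For the measured compounds named here, the only guide is the step from compound 1 to compound 2, which was a 1.1-fold higher number from compound 1 to compound 2 (0.04 log units; within the scatter). Because that step from compound 1 to compound 2 was a 1.1-fold higher number from compound 1 to compound 2 (0.04 log units; within the scatter), compound 4 is expected to sit close to compound 3, with an estimated step of a 1.1-fold higher number from compound 3 to compound 4 (0.04 log units; within the scatter). In this assay compound 4 is therefore estimated at 12500 nM, expected to fall between 6000 nM and 26000 nM.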

Compound 4, half-maximal inhibitory concentration: 8850 nM
Compound 4: middle estimate off by 1.4-fold (0.15 log units), on the high side; the range from low to high includes it.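

In this assay, 3-nitrophenyl in place of 4-methylphenyl on a carbonyl carbon gave a 1.3-fold lower number from compound 3 to compound 4 (0.11 log units; within the scatter), and this agrees with the same change on the core of compound 1: the same change on two cores in this assay, a 1.1-fold higher number (0.04 log units; within the scatter) from compound 1 to compound 2 and a 1.3-fold lower number (0.11 log units; within the scatter) from compound 3 to compound 4, 1.4-fold (0.15 log units) apart, within the scatter of two such steps

The exchange of groups on the amine nitrogen in a ring, read with 3-nitrophenyl in place, gave a 1.5-fold lower number from compound 2 to compound 4 (0.18 log units; within the scatter), and this too agrees with the same exchange read with 4-methylphenyl in place: the same change on two cores in this assay, a 1.1-fold lower number (0.04 log units; within the scatter) from compound 1 to compound 3 and a 1.5-fold lower number (0.18 log units; within the scatter) from compound 2 to compound 4, 1.4-fold (0.15 log units) apart, within the scatter of two such steps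

So on these two cores the change carries over with no difference that can be told from the scatter, but every step here lies within the scatter, so the agreement concerns steps too small to be set apart, and it does not show that the change has an effect of its own on either core or that it would behave alike on a core that gives a larger step.

The compounds shown leave open whether another group on the carbonyl carbon, such as an aminophenyl ring, a carboxyphenyl ring or a longer alkyl chain, would move the number beyond the scatter on either core. They also leave open whether an acetyl group or a short alkyl chain on the amine nitrogen in a ring would do so, and whether any larger step would then carry from one core to another.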